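Methyl branching on the ketone chain in two core variants

The source may hold more compounds than are shown below. What is called first, only, known or untested is meant among the compounds shown, and "the series" means these compounds.

Measured so far in an assay on membranes from CHO cells for displacement of a labelled ligand from adenosine receptor A1 (Homo sapiens), read by scintillation counting, with a stated time of 60 min, tested at 1 uM; on this read-out higher numbers stand for more inhibition at the one concentration tested (going by the name of the read-out) and lower numbers for less inhibition:
compound 1 `CCCC(=O)C1=C(C)NC(=O)NC1c1ccco1` — 1%
compound 2 `CC1=C(C(=O)CC(C)C)C(c2ccco2)NC(=O)N1` — 16%
compound 3 `CCCC(=O)C1=C(C)NC(=O)NC1c1cccs1` — 2%

Two changes have been made on the core of compound 1. The first is methyl in place of hydrogen on a saturated chain carbon bound to two saturated chain carbons; on this change the read-out moved by a number 15 percentage points higher from compound 1 to compound 2 (beyond the scatter). The second is thiophen-2-yl in place of furan-2-yl on a saturated ring carbon; here the read-out moved by a number 1 percentage points higher from compound 1 to compound 3 (within the scatter), so compound 1 and compound 3 cannot be told apart on this measure. Compound 3 and compound 2 do differ: the number for compound 2 lies beyond the scatter above that of compound 3, as it does above that of compound 1.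

Compound 4 `CC1=C(C(=O)CC(C)C)C(c2cccs2)NC(=O)N1` has not yet been measured in this assay. Against compound 3 it carries methyl in place of hydrogen on a saturated chain carbon bound to two saturated chain carbons, the same change that turns compound 1 into compound 2, and the two cores differ only by the change already described between compound 1 and compound 3. A single measured pair carries this change, so whether its effect carries over to the second core rests on that one pair alone.

For compound 4 a step of a number 15 percentage points higher from compound 3 to compound 4 (beyond the scatter) is expected, because a number 15 percentage points higher from compound 1 to compound 2 (beyond the scatter) on the otherwise matching pair. The estimate for compound 4 is therefore 17%, with an expected range from 5% to 30%.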

Compound 4, a percentage reported as inhibition, at one concentration (the size of the read-out at that concentration, not a potency): 19%
The estimate for compound 4 lay 2 percentage points below the measured number, within the range that was stated.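

In this assay, methyl in place of hydrogen on a saturated chain carbon bound to two saturated chain carbons gives a number 17 percentage points higher from compound 3 to compound 4 (beyond the scatter), and this step matches the one on the core of compound 1: the same change on two cores in this assay, a number 15 percentage points higher (beyond the scatter) from compound 1 to compound 2 and a number 17 percentage points higher (beyond the scatter) from compound 3 to compound 4, 2 percentage points apart, within the scatter of two such steps

Thiophen-2-yl in place of furan-2-yl gives a number 3 percentage points higher from compound 2 to compound 4 (within the scatter), so compound 2 and compound 4 cannot be told apart, and the two steps for this swap also agree: the same change on two cores in this assay, a number 1 percentage points higher (within the scatter) from compound 1 to compound 3 and a number 3 percentage points higher (within the scatter) from compound 2 to compound 4, 2 percentage points apart, within the scatter of two such steps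

This shows that propylcarbonyl to isobutylcarbonyl carried over between these two cores, which differ only in the furan-2-yl or thiophen-2-yl group, but it rests on just two pairs read at one concentration, gives no potency, and does not show that the step would hold on any other core or explain why it occurs.

The compounds shown leave open whether a longer chain such as pentylcarbonyl or a more branched one such as tert-butylcarbonyl would give a step of similar size in this assay. They also leave open whether the methyl step would persist with a phenyl group in place of furan-2-yl or thiophen-2-yl.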